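The compounds below may be only part of what the source reports. "The series", "measured", "known", "first", "only" and "open" are said of these compounds alone.

Of the compounds shown here, two on the shared core have been measured so far in a functional assay on COLO 320 cells (Homo sapiens) for cytotoxicity, read by colony formation (a lower number here means a stronger inhibitor, a higher number a weaker inhibitor), as the basis for this comparison. Compound 1 `COC(=O)C1=CO[C@@H](O[C@@H]2O[C@H](COC(c3ccccc3)(c3ccccc3)c3ccccc3)[C@@H](O)[C@H](O)[C@H]2O)[C@@H]2[C@@H](C)[C@@H](O)C[C@H]12` gives 1.4 ug/mL while compound 2 `CCCCCCCCCCCC(=O)OC[C@H]1O[C@@H](O[C@@H]2OC=C(C(=O)OC)[C@H]3C[C@H](OC(C)=O)[C@H](C)[C@@H]23)[C@H](OC(C)=O)[C@@H](OC(C)=O)[C@@H]1OC(C)=O` gives 0.24 ug/mL and so holds the lower of the two numbers, by a gap beyond the usual scatter. Compound 3 `COC(=O)C1=CO[C@@H](O[C@@H]2O[C@H](COC(=O)c3cccc([N+](=O)[O-])c3)[C@@H](OC(C)=O)[C@H](OC(C)=O)[C@H]2OC(C)=O)[C@@H]2[C@@H](C)[C@@H](OC(C)=O)C[C@H]12` differs from compound 2 in one place, counted as 3-nitrophenyl in place of undecyl on a carbonyl carbon in the structures, which is 3-nitrophenyl in place of undecyl on a carbonyl carbon. Among the measured compounds shown here, no measured step isolates this change, so any expectation is loose. A modest rise in the number is expected, staying near the span set by compound 2 at 0.24 ug/mL and compound 1 at 1.4 ug/mL in the data. The expected change is a 2.5-fold higher number from compound 2 to compound 3 (0.40 log units; beyond the scatter) as a small weakening. For compound 3 the estimated value is 0.6 ug/mL with an expected range from 0.15 ug/mL to 2.5 ug/mL in this measurement.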

Compound 3, half-maximal inhibitory concentration: 8.2 ug/mL
Compound 3: middle estimate off by 14-fold (1.14 log units), on the low side; the measured number lies above the stated range.
By their numbers in this assay, from the lowest: compound 2; then compound 1; then compound 3.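

In this assay, replacing undecyl with 3-nitrophenyl on a carbonyl carbon gives a 34-fold higher number from compound 2 to compound 3 (1.53 log units; beyond the scatter), a large step beyond the scatter. Among the compounds shown here, this is the first change in a single place, and it shows that the number responds strongly to the group held on this carbonyl carbon while the rest of compound 2 stays the same, which the earlier pair, differing in more than one place, could not show. For the compounds shown here, nothing available explains why this exchange moves the number so far.

The compounds shown leave open whether the step follows from losing undecyl or from gaining 3-nitrophenyl. A plain phenyl, a shorter alkyl chain such as hexyl or a longer chain on the same carbonyl carbon could separate these two readings.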